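Adding (dimethylamino)methyl to compound 1

The source may hold more compounds than are shown below. What is called first, only, known or untested is meant among the compounds shown, and "the series" means these compounds.

Measured so far in a functional assay on HCT-116 cells (Homo sapiens) for cytotoxicity, read by MTT assay, with a stated time of 3 days; on this read-out lower numbers stand for stronger inhibition and higher numbers for weaker inhibition:
compound 1 `CC(C)(C)c1cc2c(N/N=C/c3ccccc3)ncnc2s1`: "not determined" (no result reported)
compound 2 `CN(C)S(=O)(=O)c1ccc(/C=N/Nc2ncnc3sc(C(C)(C)C)cc23)cc1`: 1.42 ug/mL

Compound 1 offers no baseline. In this assay, as far as these compounds go, compound 1 stands at "not determined" (no result reported) (no single number exists for it), so any comparison with it remains open. Going by the values given here, the only number available on this core comes from compound 2 (1.42 ug/mL), which carries a different substituent on the same aromatic ring.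

Attention now turns to compound 3 `CN(C)Cc1cccc(/C=N/Nc2ncnc3sc(C(C)(C)C)cc23)c1`, which has yet to be measured. The structural change is (dimethylamino)methyl in place of hydrogen on an aromatic carbon and consists of (dimethylamino)methyl in place of hydrogen on an aromatic carbon, meta to a large group.

Among the compounds with values here, no measured step shows what such a change does, and the size of any step from the unmeasured compound 1 cannot be stated. The expectation therefore leans on compound 2 (1.42 ug/mL) alone: a result in the same region, with no difference beyond the usual scatter in either direction. In this assay the expected value for compound 3 is estimated at 2 ug/mL (range 0.6 ug/mL to 7 ug/mL).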

Compound 3, half-maximal inhibitory concentration: 0.405 ug/mL
The estimate for compound 3 lay 4.9-fold (0.69 log units) above the measured number; the measured number lies below the stated range.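

No step can be read from compound 1 to compound 3 in this assay: compound 3 gives 0.405 ug/mL, while compound 1 offers no single number for comparison. The compounds shown leave open how much the added (dimethylamino)methyl itself changes the value on the shared core. Nothing shown offers an explanation for this result.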